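Replacing 3,4-dichlorophenyl with 4-cyanophenyl on a shared core

This account rests on a few compounds, and the source may have more. Where it says the series, first, only, none or still open, it means among the compounds named here.

Compound 1 `COc1cc(/C=C2\CN(C)C/C(=C\c3ccc(Cl)cc3)C2=O)cc(OC)c1OC` and compound 2 `COc1cc(/C=C2\CN(C)C/C(=C\c3ccc(Cl)c(Cl)c3)C2=O)cc(OC)c1OC` share one core. Among the compounds with values here, in a functional assay on HeLa cells (Homo sapiens) for cytotoxicity, read by MTT assay, with a stated time of 24 h (a lower number here means a stronger inhibitor, a higher number a weaker inhibitor), compound 2 gives 13500 nM, the only actual number available so far. Compound 1 gives > 20000 nM, which is a limit of the assay and not a number.

Compound 3 `COc1cc(/C=C2\CN(C)C/C(=C\c3ccc(C#N)cc3)C2=O)cc(OC)c1OC` has 4-cyanophenyl in place of 3,4-dichlorophenyl on a double-bonded chain carbon bound to a double-bonded ring carbon.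

Within the data shown here, only one measured step bears on this change: an at least 1.4-fold lower number from compound 1 to compound 2 (0.17 log units; that floor lies within the scatter), with chloro in place of hydrogen on an aromatic carbon. That step is small and only loosely relevant, since the new group differs from a simple hydrogen. Compound 3 carries no chloro, so a shift toward a weaker result is the likelier direction, though no change beyond the scatter is expected. The expected step is a 1.2-fold higher number from compound 2 to compound 3 (0.07 log units; within the scatter). A result at the assay's ceiling is a real possibility, given (the limit of > 20000 nM in this assay, at which 1 of the 2 values shown sits). For compound 3 the estimated value in this assay is 16000 nM, with an expected range from 8000 nM to 30000 nM.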

Compound 3, half-maximal inhibitory concentration: 3420 nM
The estimate for compound 3 lay 4.7-fold (0.67 log units) above the measured number; measured number below the stated range.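

In this assay, within the data shown here, the aryl group on the double-bonded chain carbon bound to a double-bonded ring carbon proves able to move the result clearly: 4-cyanophenyl in place of 3,4-dichlorophenyl gives a 3.9-fold lower number from compound 2 to compound 3 (0.60 log units; beyond the scatter), the first step here that lies beyond the scatter with real numbers at both ends. Cyano in place of chloro on an aromatic carbon gives an at least 5.8-fold lower number from compound 1 to compound 3 (0.76 log units; beyond the scatter), so compound 3, the only one of the three without chloro, is the strongest inhibitor of the set. That second step is only a floor on the true size, because compound 1 stands at a limit of the assay and not at a number: the limit of > 20000 nM in this assay, at which 1 of the 3 values shown sits.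

With a single nitrile-bearing compound, the values do not show whether the nitrile itself matters or whether another group on that aromatic carbon, such as a nitro group, a carboxylic acid or an amine, would serve as well. They also leave open whether the same step would hold with a different group on the other side of the shared core.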